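Bromo for Methoxy on a Shared Oxadiazole Core

The compounds below may be only part of what the source reports. "The series", "measured", "known", "first", "only" and "open" are said of these compounds alone.

The pair measured so far are compound 1 `COc1ccc(-c2nnc(Nc3ncccn3)o2)cc1` and compound 2 `COc1ccc(-c2nnc(Nc3ncccn3)o2)cc1OC`. In a functional assay, with a stated time of 30 min, tested at 20 uM (on this read-out lower numbers stand for less inhibition and higher numbers for more inhibition at the one concentration tested (going by the name of the read-out)), compound 1 gives 45.8%, while compound 2 gives 49.5%. Among the compounds with values here, compound 1 stands lowest of the two numbers, but the only step, a number 3.7 percentage points higher from compound 1 to compound 2 (within the scatter), lies within the scatter, so the two cannot be set apart.

Compound 3 `Brc1ccc(-c2nnc(Nc3ncccn3)o2)cc1` is not yet measured. It differs from compound 1 by bromo in place of methoxy on an aromatic carbon. Within the data shown here, no measured step bears directly on this change: the one step known concerns methoxy in place of hydrogen at a different aromatic carbon, and it was within the scatter. With nothing to lean on, an expectation for compound 3 rests on the shared core alone, and no step beyond the scatter is expected in this assay. The estimate for compound 3 is therefore 45%, with a range of 25% to 65%, a step of a number 0.8 percentage points lower from compound 1 to compound 3 (within the scatter).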

Compound 3, a percentage reported as inhibition, at one concentration (the size of the read-out at that concentration, not a potency): 47.8%
Beside the measured number, compound 3's estimate is 2.8 percentage points below it; the range from low to high includes it.
By their numbers in this assay, from the lowest: compounds 1, 3 and 2 (each within the scatter of the next).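

At the aromatic carbon para to a large group, bromo in place of methoxy gives a step that cannot be told from the scatter in this assay (a number 2 percentage points higher from compound 1 to compound 3 (within the scatter)). Unlike the earlier step, which added a methoxy at another aromatic carbon, this change replaces the methoxy at this position, and the read-out stays within the scatter even though the entering bromo has no hydrogen-bond acceptor and the leaving methoxy has one. Nothing measured independently explains why this exchange leaves the number within the scatter.

Going by these compounds, whether an amine, a carboxylic acid or a longer chain at this carbon would give a step beyond the scatter remains open. Each number is also a single-concentration inhibition reading, so the compounds shown leave potency itself unsettled.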